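The source may hold more compounds than are shown below. What is called first, only, known or untested is meant among the compounds shown, and "the series" means these compounds.

Notes on the series. In a functional assay on HepG2 cells (Homo sapiens) for cytotoxicity, read by MTT assay, with a stated time of 72 h (a lower number here means a stronger inhibitor, a higher number a weaker inhibitor), compound 1 `CCCCCN(CCCCC)c1nc2c(ncn2-c2ccccc2)c(=O)n1-c1ccc(Cl)cc1` gives only a limit, > 100000 nM. Compound 2 `CCNc1nc2c(ncn2-c2ccccc2)c(=O)n1-c1ccccc1` likewise reaches only a limit in this assay, > 100000 nM. Both values shown therefore sit at the limit of > 100000 nM in this assay, at which 2 of the 2 values shown sit, and compound 1 stands at that limit without a number of its own; nothing on the numbers shown separates it from compound 2. Compound 3 `O=c1c2ncn(-c3ccccc3)c2nc(NCc2ccccc2)n1-c1ccc(Cl)cc1` is not yet measured in this assay. It differs from compound 1 by benzylamino in place of dipentylamino on an aromatic carbon. No measured step between compounds of this series exists, so no size can be read for this change; with the shown values at the limit, no change beyond the scatter is expected and a further limit is the likeliest outcome. Compound 3 is expected to give 100000 nM in this assay, within 30000 nM to 300000 nM. The expected step from compound 1 to compound 3 is a number no higher from compound 1 to compound 3 (the limit leaves the size open), an estimate only.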

Compound 3, half-maximal inhibitory concentration: 62100 nM
Estimate against measurement, compound 3: 1.6-fold (0.21 log units) above, within the range that was stated.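

In this assay compound 3 gives the first reading shown that is a number and not a limit, so this position, on an aromatic carbon between two ring nitrogen atoms, can carry a group that yields a value inside the range of the assay. The change from dipentylamino to benzylamino is a step of an at least 1.6-fold lower number from compound 1 to compound 3 (0.20 log units; that floor lies within the scatter), and as compound 1 holds only a limit, the true size of the step stays unread. The series as shown still sits mostly at the edge of that range: the limit of > 100000 nM in this assay, at which 2 of the 3 values shown sit.

As far as these compounds go, whether the reading goes with the aromatic ring of benzylamino or with the hydrogen on its nitrogen stays open. Cyclohexylmethylamino and benzyl(methyl)amino at this position would separate the two.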